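Fluoro for hydrogen: compound 2 to compound 3

This account rests on a few compounds, and the source may have more. Where it says the series, first, only, none or still open, it means among the compounds named here.

Measured compounds:
compound 1 `CCOC(=O)c1sc(-c2ccccc2)nc1N1CCC(NCc2ccc(F)cc2)CC1`: 6.23%
compound 2 `CCOC(=O)c1sc(-c2ccccn2)nc1N1CCC(NCc2ccccc2)CC1`: 14.6%

In an ADME assay on RAW264.7 cells (Mus musculus) for cytotoxicity, read by MTT assay, with a stated time of 72 h, tested at 50 uM (on this read-out lower numbers stand for less inhibition and higher numbers for more inhibition at the one concentration tested (going by the name of the read-out)), compound 1 gives 6.23%, and in this assay compound 2 gives 14.6%. Compound 2 carries the higher of the two numbers, but the gap to compound 1 lies within the scatter, so the two cannot be ranked. Compounds 1 and 2 differ in two places at once, so no single step can be read between them. Both numbers sit low in this assay.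

Compound 3 `CCOC(=O)c1sc(-c2ccccn2)nc1N1CCC(NCc2ccc(F)cc2)CC1` differs from compound 2 only by fluoro in place of hydrogen on an aromatic carbon. For the measured compounds named here, no measured pair isolates this change, so nothing is known about its effect in this assay. The step of a number 2.6 percentage points lower from compound 2 to compound 3 (within the scatter) is expected to stay within the scatter, with no direction beyond it. Compound 3 is expected to give 12% in this assay, within the range 0% to 28%.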

Compound 3, a percentage reported as inhibition, at one concentration (the size of the read-out at that concentration, not a potency): 12.6%
Compound 3: middle estimate off by 0.6 percentage points, on the low side; low and high end bracket the measured number.
By their numbers in this assay, from the lowest: compounds 1, 3 and 2 (each within the scatter of the next).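

For the compounds shown here, compound 3 gives the first single-place reading of both changes that separated compound 1 from compound 2. In this assay, fluoro in place of hydrogen on the benzyl group gives a number 2 percentage points lower from compound 2 to compound 3 (within the scatter) with the pyridin-2-yl group held constant, so 4-fluorobenzyl and benzyl cannot be told apart here. With the 4-fluorobenzylamino group held constant, pyridin-2-yl in place of phenyl gives a number 6.4 percentage points higher from compound 1 to compound 3 (within the scatter) and likewise cannot be told apart, and nothing available explains either step.

From the compounds shown here alone, whether a chloro, methoxy or trifluoromethyl group at this same place on the benzyl ring would give a step beyond the scatter remains open. The compounds shown also leave open how a carboxylic acid or an amide in place of the ethyl ester would read in this assay.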